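Fluoro for Chloro: Forecast for Compound 3

A few compounds are considered here, and "the series" means these few. Any claim that something is new, unique, unknown or untested is made for them only; others in the source may bear on it.

Of the compounds shown here, two have so far been measured in an assay on cells for inhibition of Amine oxidase [flavin-containing] B (Homo sapiens); on this read-out lower numbers stand for stronger inhibition and higher numbers for weaker inhibition. Compound 1, `O=C(NCc1ccc(Cl)c(Cl)c1)c1ccc2[nH]ncc2c1`, gives 388 nM in this assay. Compound 2, `O=C(Nc1ccc(F)c(Cl)c1)c1ccc2cn[nH]c2c1`, gives 234 nM in this assay. Of the two numbers, compound 2 carries the lower one, but its gap to compound 1 lies within the usual scatter, so the two stand level on the evidence at hand. Compound 3, `O=C(Nc1ccc(F)c(F)c1)c1ccc2cn[nH]c2c1`, has not yet been measured. It differs from compound 2 in one place: fluoro in place of chloro on an aromatic carbon, a fluoro in place of chloro on an aromatic carbon. Going by the values given here, no measured pair shows this particular exchange, so the size of the step rests on judgment alone. In this assay compound 3 is expected to come out somewhat weaker, a step of a 1.9-fold higher number from compound 2 to compound 3 (0.28 log units; within the scatter) that may well stay within the scatter. For compound 3 the estimated value in this assay is 450 nM, with a range from 150 nM to 1400 nM.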

Compound 3, half-maximal inhibitory concentration: 1300 nM
The estimate for compound 3 lay 2.9-fold (0.46 log units) below the measured number; the measured number falls inside the stated range.
By their numbers in this assay, from the lowest: compounds 2 and 1 (each within the scatter of the next); then compound 3.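

In this assay, going by these compounds alone, the exchange of chloro for fluoro on this aromatic carbon, ortho to a fluoro group and meta to a large group, gives a 5.6-fold higher number from compound 2 to compound 3 (0.74 log units; beyond the scatter) and is the first single change that can be read as a step. At this position the two groups are therefore not interchangeable: the chloro of compound 2 goes with clearly stronger inhibition than the fluoro of compound 3. Nothing shown bears on why the step has this size.

The compounds shown leave open how a bromo, a methyl or a methoxy group on this same carbon would read in this assay against the chloro of compound 2. They also leave open whether the same exchange would carry over to compound 1, which differs from compound 2 in more than one place.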